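From chloro to methoxy in a small series

The source may report more compounds than this note shows. Statements on the series, on what has been measured and on what is new or still open speak of the compounds shown alone.

Among the compounds with values here, in a functional assay on cells (Erythrocyte, Rattus norvegicus) for inhibition, read by hemolysis, with a stated time of 1 h (on this read-out lower numbers stand for stronger inhibition and higher numbers for weaker inhibition), compound 1 `COc1cc(OC)c(OC)cc1/C=C/C(=O)c1ccc(Cl)cc1` gives 2.3 ug/mL and compound 2 `COc1cc(OC)c(OC)cc1/C=C/C(=O)c1cc(OC(C)=O)ccc1OC(C)=O` gives 2.33 ug/mL and these two values lie within the scatter of each other, so compound 1 stands level with its only measured neighbour. Compound 3 `COc1ccc(C(=O)/C=C/c2cc(OC)c(OC)cc2OC)cc1` has not yet been measured. It keeps the core of compound 1 and differs at one place: methoxy in place of chloro on an aromatic carbon with methoxy in place of chloro on an aromatic carbon, turning 4-chlorophenyl into 4-methoxyphenyl. Within the data shown here, no measured pair isolates this change, so its size cannot be read directly from the data. Compound 1 and compound 2 differ in structure, yet compound 2 still reads 2.33 ug/mL in this assay and this gives no sign of a steep response. The expected step of a 1.1-fold higher number from compound 1 to compound 3 (0.04 log units; within the scatter) stays within the scatter, in no particular direction. For compound 3 the estimate is 2.5 ug/mL with an expected range of 1.2 ug/mL to 5.2 ug/mL in this measurement.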

Compound 3, half-maximal inhibitory concentration: 2.18 ug/mL
The estimate for compound 3 lay 1.1-fold (0.06 log units) above the measured number, and the stated range covers the measured number.
By their numbers in this assay, from the lowest: compounds 3, 1 and 2 (each within the scatter of the next).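

In this assay, methoxy in place of chloro on an aromatic carbon, para to a large group, now has a measured size: a 1.1-fold lower number from compound 1 to compound 3 (0.02 log units; within the scatter). This is the only pair shown that isolates a single change, and it indicates that, on this read-out, 4-chlorophenyl and 4-methoxyphenyl cannot be told apart at this position, even though methoxy carries a hydrogen-bond acceptor and chloro does not. Nothing available bears on why the two groups read alike.

The compounds shown leave open whether this position tolerates change in general or whether these two groups simply happen to match. An amine, a carboxylic acid or a longer chain such as butoxy at the same place could still separate from compound 1, and the present data cannot say whether any would.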